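The source may report more compounds than this note shows. Statements on the series, on what has been measured and on what is new or still open speak of the compounds shown alone.

Three chalcone-type boronic acids sharing one core have been tested in a functional assay on HCT-116 cells (Homo sapiens) for cytotoxicity, read by MTT assay, with a stated time of 48 h; a higher number here means a weaker inhibitor, a lower number a stronger inhibitor. Compound 3 `O=C(/C=C/c1ccc2c(c1)B(O)OC2)c1ccccc1F` gives 4200 nM, the lowest number among those measured. Compound 2 `Cc1ccc(C(=O)/C=C/c2ccc3c(c2)B(O)OC3)cc1` gives 10500 nM. Compound 1 `Cn1cccc1C(=O)/C=C/c1ccc2c(c1)B(O)OC2` gives > 100000 nM in this assay, which is a limit and not a number. Compound 4 `O=C(/C=C/c1ccc2c(c1)B(O)OC2)c1ccccc1O` differs from compound 3 by hydroxy in place of fluoro on an aromatic carbon. The measured steps, an at least 9.5-fold lower number from compound 1 to compound 2 (0.97 log units; beyond the scatter), an at least 23-fold lower number from compound 1 to compound 3 (1.37 log units; beyond the scatter) and a 2.5-fold lower number from compound 2 to compound 3 (0.40 log units; beyond the scatter), each exchange the whole aryl group on the carbonyl carbon, not a single substituent, so they bear only loosely on this change. A step in this assay no larger than the scatter, in either direction, is therefore expected, a 1.1-fold higher number from compound 3 to compound 4 (0.03 log units; within the scatter). Compound 4 is estimated at 4500 nM, in a range from 1500 nM to 14000 nM.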

Compound 4, half-maximal inhibitory concentration: 77900 nM
The estimate for compound 4 lay 17-fold (1.24 log units) below the measured number; measured number above the stated range.
By their numbers in this assay, from the lowest: compound 3; then compound 2; then compound 4. At a limit, above all of these: compound 1.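

In this assay, this place on an aromatic carbon, ortho to a large group, proves sensitive to a single substituent: hydroxy in place of fluoro gives a 19-fold higher number from compound 3 to compound 4 (1.27 log units; beyond the scatter) and so moves the number well beyond the scatter, which the earlier exchanges of the whole aryl group could not show. The 2-hydroxyphenyl group also falls behind 4-methylphenyl, with a 7.4-fold higher number from compound 2 to compound 4 (0.87 log units; beyond the scatter) on that exchange. The remaining step, an at least 1.2-fold lower number from compound 1 to compound 4 (0.10 log units; that floor lies within the scatter) as printed, cannot be read as a real separation: the limit of > 100000 nM in this assay, at which 1 of the 4 values shown sits.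

From the compounds shown here alone, whether the loss of fluoro or the entry of hydroxy drives the change stays open. So does how a methoxy, an amine or a chloro group would read at this place.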